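Compound 3: methyl replaces 4-cyanophenyl in the series

This account rests on a few compounds, and the source may have more. Where it says the series, first, only, none or still open, it means among the compounds named here.

In a functional assay on HL-60 cells (Homo sapiens) for cytotoxicity, read by MTT assay, with a stated time of 48 h (on this read-out lower numbers stand for stronger inhibition and higher numbers for weaker inhibition), compound 1 `N#Cc1ccc(Cn2c(/C=C3\SC(=S)N(CC(=O)O)C3=O)nc3ccccc32)cc1` gives 7640 nM, the highest of the two numbers in hand. Compound 2 `COc1cc(Cn2c(/C=C3\SC(=S)N(CC(=O)O)C3=O)nc3ccccc32)cc(OC)c1` gives 1410 nM. That measured step is a 5.4-fold lower number from compound 1 to compound 2 (0.73 log units; beyond the scatter). Compound 3 `CCn1c(/C=C2\SC(=S)N(CC(=O)O)C2=O)nc2ccccc21` is not yet measured; it differs from compound 1 by methyl in place of 4-cyanophenyl on a saturated chain carbon bound to an aromatic nitrogen. For the measured compounds named here, the one measured step exchanged one aromatic group for another and does not show what the aromatic group itself contributes, so the direction is not fixed by the data. For compound 3 the expected step is a 1.3-fold higher number from compound 1 to compound 3 (0.12 log units; within the scatter), leaning toward a weaker number but likely inside the scatter. Compound 3 is estimated at 10000 nM, between 3000 nM and 35000 nM.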

Compound 3, half-maximal inhibitory concentration: 2120 nM
Compound 3: middle estimate off by 4.7-fold (0.67 log units), on the high side; the measured number lies below the stated range.
By their numbers in this assay, from the lowest: compounds 2 and 3 (each within the scatter of the next); then compound 1.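

In this assay, the aromatic group is not needed at this place for a number in this range: methyl in place of 4-cyanophenyl gives a stronger number (a 3.6-fold lower number from compound 1 to compound 3 (0.56 log units; beyond the scatter)). Methyl in place of 3,5-dimethoxyphenyl gives no separable change (a 1.5-fold higher number from compound 2 to compound 3 (0.18 log units; within the scatter)), so among these three compounds only 4-cyanophenyl stands apart. No available data bear on the reason for this.

Open, from the compounds shown here alone, is how a longer chain, an amine or a carboxylic acid would read on a saturated chain carbon bound to an aromatic nitrogen. Also open, going by these compounds, is whether the weaker number of compound 1 belongs to the nitrile or to the phenyl ring that carries it.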